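Trifluoromethyl gives way to bromo on the fused ring

The source may hold more compounds than are shown below. What is called first, only, known or untested is meant among the compounds shown, and "the series" means these compounds.

Compound 2 `Fc1cc(Cl)ccc1-c1ccc(Cn2nnc3c(C(F)(F)F)cccc32)cn1` stands highest of the two numbers in an ADME assay on microsomes from liver (Homo sapiens) for metabolic stability, tested at 2.5 uM (on this read-out higher numbers stand for fast clearance and lower numbers for slow clearance), at 0.04 mL/min/g; compound 1 `Fc1cc(Cl)ccc1-c1ccc(Cn2nnc3ccccc32)cn1` gives 0.01 mL/min/g. For the measured compounds named here, the single measured step, a 4.0-fold higher number from compound 1 to compound 2 (0.60 log units; beyond the scatter), is the only one that bears on the new compound. Compound 3 `Fc1cc(Cl)ccc1-c1ccc(Cn2nnc3c(Br)cccc32)cn1` differs from compound 2 by bromo in place of trifluoromethyl on an aromatic carbon. That measured step exchanged other groups, so it is only a loose guide here, and no move beyond the scatter is expected. The estimated step is a 1.3-fold lower number from compound 2 to compound 3 (0.12 log units; within the scatter). Compound 3 is therefore expected near 0.03 mL/min/g, within 0.01 mL/min/g to 0.08 mL/min/g.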

Compound 3, intrinsic clearance in a liver preparation (reported as CLH), per the amount of preparation that the assay uses: 0.1 mL/min/g
Estimate against measurement, compound 3: 3.3-fold (0.52 log units) below; measured number outside the range, above it.
By their numbers in this assay, from the lowest: compound 1; then compound 2; then compound 3.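

Bromo in place of trifluoromethyl gives a 2.5-fold higher number from compound 2 to compound 3 (0.40 log units; beyond the scatter) in this assay and so shows that this aromatic carbon, ortho to a fused ring, tells these two groups apart. Set against hydrogen, bromo gives a 10-fold higher number from compound 1 to compound 3 (1.00 log units; beyond the scatter) as the widest step among the three compounds, and both groups on this carbon raise the number, with no compound here going against that. On these data alone, whether an amine or a methoxy group on the same carbon would stay near compound 1 or rise past compound 3 remains open. Nothing available here explains the difference between bromo and trifluoromethyl.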